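The compounds below may be only part of what the source reports. "The series", "measured", "known", "first", "only" and "open" are said of these compounds alone.

Measured compounds:
compound 1 `O=C(Nc1ccccc1O)c1cccc(N2C(=O)c3ccccc3C2=O)c1` — 77 nM
compound 2 `COc1ccccc1C(=O)Nc1cccc(NC(=O)c2ccc(F)cc2)c1` — > 30000 nM

The two measured compounds were tested in an in vitro functional assay on HEK293-A cells for antagonist activity at metabotropic glutamate receptor 5 (Rattus norvegicus), read by calcium flux; a higher number here means a weaker inhibitor, a lower number a stronger inhibitor. Compound 1 gives 77 nM there. Compound 2 is a different case: in this assay compound 2 gives only a limit, > 30000 nM, so no number is known for it. Within the data shown here, that limit is described in the limit of > 30000 nM in this assay, at which 1 of the 2 values shown sits, and compound 2 is the one of the two values that sits at it. Compound 2 therefore stands at the weak end of what the assay can report, with nothing further to place it against compound 1, whose structure has no single-point relation to it.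

Compound 3 `COc1ccccc1C(=O)Nc1cccc(NC(=O)C2CCC2)c1` is not yet measured. It differs from compound 2 in one place: cyclobutyl in place of 4-fluorophenyl on a carbonyl carbon. Among the measured compounds shown here, no measured step between compounds is known here, so the size of the change can only be expected. For compound 3 the step of a number no higher from compound 2 to compound 3 (the limit leaves the size open) is expected to be none beyond the scatter, since the starting point is a limit. Compound 3 is estimated at 30000 nM, with a range from 8000 nM to 100000 nM, and most likely the assay will again report only a limit.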

Compound 3, half-maximal inhibitory concentration: > 30000 nM
Compound 3: no number, only a limit (the forecaster's own chance of this, stated with the estimate: 75%); the middle value lies on the limit itself.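

Compound 2 and compound 3 both give only a limit, so no step can be read between them: the limit of > 30000 nM in this assay, at which 2 of the 3 values shown sit.

The compounds shown leave open whether cyclobutyl in place of 4-fluorophenyl on the carbonyl carbon changes inhibition at all, and how weak either compound actually is.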